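The source may report more compounds than this note shows. Statements on the series, on what has been measured and on what is new or still open speak of the compounds shown alone.

Compound 1 `O=C(O)CSc1ccc(NCc2cccc(Oc3ccccc3)c2)cc1` and compound 2 `O=C(O)[C@@H]1C[C@H]1c1ccc(NCc2cccc(Oc3ccccc3)c2)cc1` share one core and differ only in the acid-bearing arm. In a functional assay on CHO cells for agonist activity at Free fatty acid receptor 1 (Homo sapiens) (a lower number here means that less compound is needed, a higher number that more compound is needed for the effect), compound 1 gives 324 nM, and compound 2 gives 562 nM; the step of a 1.7-fold higher number from compound 1 to compound 2 (0.24 log units; within the scatter) shows that exchanging one carboxylic acid arm for another changed little. Compound 2 thus stands at the upper end of the two numbers, but its gap to compound 1 lies within the scatter. Compound 3 `NC(=O)CCc1ccc(NCc2cccc(Oc3ccccc3)c2)cc1` carries the change (2-carbamoylethyl in place of 2-carboxycyclopropyl on an aromatic carbon), which removes the carboxylic acid altogether. Among the measured compounds shown here, the only measured step kept the acid, so it offers no guide to such a loss. For compound 3 a clearly higher number is expected, an 8.9-fold higher number from compound 2 to compound 3 (0.95 log units; beyond the scatter), with an estimate of 5000 nM and a range from 1000 nM to 30000 nM.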

Compound 3, half-maximal effective concentration: 51.3 nM
Estimate against measurement, compound 3: 97-fold (1.99 log units) above; the measured number lies below the stated range.
By their numbers in this assay, from the lowest: compound 3; then compounds 1 and 2 (each within the scatter of the next).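

In this assay the 2-carbamoylethyl arm gives an 11-fold lower number from compound 2 to compound 3 (1.04 log units; beyond the scatter) and a 6.3-fold lower number from compound 1 to compound 3 (0.80 log units; beyond the scatter) against arms that end in a carboxylic acid. A carboxylic acid at this position is therefore not needed for the effect in these compounds, and compound 3 has the lowest number of the three. The step to compound 3 also removes the three-membered ring and both stereocentres, so several changes travel together. A 2-carboxyethyl arm would help separate the amide from the open chain, while an amine would probe the position further. No measurement here explains the drop.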